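From 3-hydroxybenzyl to 3,4-dihydroxyphenyl on compound 1

The source may hold more compounds than are shown below. What is called first, only, known or untested is meant among the compounds shown, and "the series" means these compounds.

Within the data shown here, in a functional assay on HeLa cells (Homo sapiens) for inhibition, read by CCK-8 assay, with a stated time of 48 h (on this read-out lower numbers stand for stronger inhibition and higher numbers for weaker inhibition), compound 1 `O=S(=O)(NCCNC(=S)Nc1cc(C(F)(F)F)cc(C(F)(F)F)c1)c1ccc(-c2ccccc2OCc2cccc(O)c2)s1` gives 14900 nM and this is the only true number available so far. Compound 2 `COc1ccc(Oc2ccccc2-c2ccsc2S(=O)(=O)N2CCN(C(=O)Nc3ccc(F)cc3)CC2)cc1OC` reads > 20000 nM and that is a limit of the assay, not a number. Compound 3 `COc1ccc(NC(=O)NCCNS(=O)(=O)c2ccc(-c3ccccc3Oc3ccc([N+](=O)[O-])cc3)s2)cc1` reads > 20000 nM as a limit too. The picture so far is therefore dominated by the limit of > 20000 nM in this assay, at which 2 of the 3 values shown sit, and offers little else for comparison.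

The next compound to be tested is compound 4 `O=S(=O)(NCCNC(=S)Nc1cc(C(F)(F)F)cc(C(F)(F)F)c1)c1ccc(-c2ccccc2Oc2ccc(O)c(O)c2)s1` which keeps the rest of compound 1 unchanged. On an oxygen on an aromatic ring, 3,4-dihydroxyphenyl stands in place of 3-hydroxybenzyl (3,4-dihydroxyphenyl in place of 3-hydroxybenzyl on an oxygen on an aromatic ring). Put another way, the change runs from (3-hydroxybenzyl)oxy to 3,4-dihydroxyphenoxy.

Among the measured compounds shown here, no two measured compounds differ in just one place, so no measured step shows how large such a change might be. The expectation rests on compound 1 with its 14900 nM as the only anchor. In this assay the expected shift is a 1.7-fold lower number from compound 1 to compound 4 (0.22 log units; within the scatter) and this estimate stays within the usual scatter, with only a slight lean toward stronger inhibition. For compound 4 the estimated value is 9000 nM with an expected range of 2500 nM to 20000 nM for the coming measurement.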

Compound 4, half-maximal inhibitory concentration: > 20000 nM
Compound 4: no number, only a limit; the forecaster's own chance of this, stated with the estimate: 20%; at least 2.2-fold (0.34 log units) between middle value and limit.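

In this assay, among these compounds, the change from 3-hydroxybenzyl to 3,4-dihydroxyphenyl gives the first step that can be read at this position, an at least 1.3-fold higher number from compound 1 to compound 4 (0.12 log units; that floor lies within the scatter). Compound 4 reads > 20000 nM, and that is a limit of the assay, not a number. The step is therefore only a floor that does not rise beyond the scatter, so this change shows no sign of stronger inhibition, and compound 4 joins the other compounds at the top of the measurable range: the limit of > 20000 nM in this assay, at which 3 of the 4 values shown sit.

Among the compounds shown, only compound 1 gives a true number, 14900 nM, so the size of the change from 3-hydroxybenzyl to 3,4-dihydroxyphenyl remains unknown. As far as these compounds go, it also remains open whether an amine, a carboxylic acid or a longer chain on this oxygen would bring the value clearly under the limit and give this position a measured effect.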